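This account rests on a few compounds, and the source may have more. Where it says the series, first, only, none or still open, it means among the compounds named here.

Measured so far in a functional assay on MDA-MB-231 cells (Homo sapiens) for inhibition, with a stated time of 48 h; a higher number here means that more compound is needed for the effect, a lower number that less compound is needed:
compound 1 `CN[C@@H](C)C(=O)N[C@@H](CCCCNc1ccc([N+](=O)[O-])cc1[N+](=O)[O-])C(=O)N1CCC[C@H]1C(=O)NC(c1ccccc1)c1ccccc1`: 44700 nM
compound 2 `CN[C@@H](C)C(=O)N[C@@H](CO)C(=O)N1CCC[C@H]1C(=O)NC(c1ccccc1)c1ccccc1`: > 100000 nM

Compound 1 gives a numerical result in this assay. For compound 2 the value is only a limit of the assay, not a number, as it sits at the limit of > 100000 nM in this assay, at which 1 of the 2 values shown sits. Compound 3 `CN[C@@H](C)C(=O)N[C@@H](CCCCN)C(=O)N1CCC[C@H]1C(=O)NC(c1ccccc1)c1ccccc1` differs from compound 2 by 3-aminopropyl in place of hydroxy on a saturated chain carbon, two bonds along the chain from an amide-type nitrogen and a carbonyl carbon. No measured step of this kind exists among these compounds, and with compound 2 known only as a limit, the size of the step cannot be read from the data. The step from compound 2 to compound 3 is expected to be an at least 1.6-fold lower number from compound 2 to compound 3 (0.22 log units; that floor lies within the scatter). Compound 3 is estimated at 60000 nM, with a range from 15000 nM to 200000 nM.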

Compound 3, half-maximal effective concentration: > 100000 nM
Compound 3 gave a limit, no number; the forecaster's own chance of this, stated with the estimate: 40%; at least 1.6-fold (0.22 log units) between middle value and limit.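

In this assay, compound 2 and compound 3 both stand at a limit of the assay, not a number, and the step between them cannot be read: the limit of > 100000 nM in this assay, at which 2 of the 3 values shown sit.

Swapping hydroxy for 3-aminopropyl on this saturated chain carbon thus does not by itself give a measurable value. Hydrogen in place of 2,4-dinitrophenyl on the amine nitrogen gives an at least 2.2-fold higher number from compound 1 to compound 3 (0.34 log units; beyond the scatter), so the measurable value of compound 1 goes with that added group.

From the compounds shown here alone, whether a plain phenyl or a benzoyl on that nitrogen would also give a number stays open. So does the outcome of a carboxylic acid or a longer chain at this carbon.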